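Isopropoxycarbonyl to cyclopropyl-oxadiazolyl on the ring amine nitrogen

The source may report more compounds than this note shows. Statements on the series, on what has been measured and on what is new or still open speak of the compounds shown alone.

Measured in a functional assay on isolated protein with Glucose-dependent insulinotropic receptor (Mus musculus) as the target, read by HTRF and cAMP accumulation, with a stated time of 45 min; on this read-out higher numbers stand for larger maximal responses and lower numbers for smaller maximal responses:
compound 1 `CC(C)(C)OC(=O)N1CCN(c2ncc(-c3ccc(OCC#N)cc3)cn2)CC1`: 78%
compound 2 `C[C@@H]1CN(C(=O)OC(C)(C)C)CCN1c1ncc(OCc2ccc(S(=O)(=O)N(C)C)cc2)cn1`: 39%
compound 3 `CC(C)OC(=O)N1CCN(c2ncc(OCc3ccncc3C#N)cn2)[C@H](C)C1`: 77%

Compound 3 holds the second highest of the three values. Its number and that of compound 1 lie within the scatter of each other, so no order between them is claimed; compound 2 sits well lower, beyond the scatter. No pair among these three differs in only one place, so no single-change step is available.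

Compound 4 `C[C@@H]1CN(c2noc(C3CC3)n2)CCN1c1ncc(OCc2ccncc2C#N)cn1` is not yet measured. It arises from compound 3 by 5-cyclopropyl-1,2,4-oxadiazol-3-yl in place of isopropoxycarbonyl on an amine nitrogen in a ring. Without a comparable measured step, the expectation rests only on compound 3 itself, with no marked change in either direction: the step of a number 7 percentage points lower from compound 3 to compound 4 (within the scatter) is expected to stay within the scatter. Compound 4 is therefore estimated at 70%, with a range of 40% to 95%.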

Compound 4, intrinsic activity: the largest response reached, in percent of the reference agonist's: 45%
Beside the measured number, compound 4's estimate is 25 percentage points above it; the range from low to high includes it.
By their numbers in this assay, from the lowest: compounds 2 and 4 (each within the scatter of the next); then compounds 3 and 1 (each within the scatter of the next).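

In this assay, 5-cyclopropyl-1,2,4-oxadiazol-3-yl in place of isopropoxycarbonyl on the amine nitrogen in the ring gives a number 32 percentage points lower from compound 3 to compound 4 (beyond the scatter). Among the compounds shown here, this is the first single-change reading at this position, and it shows that the maximal response depends on the group carried there. Nothing available accounts for the size of this step.

For the compounds shown here, the single step does not separate the part played by the five-membered aromatic ring from that of the cyclopropyl ring. Going by these compounds, how 5-methyl-1,2,4-oxadiazol-3-yl or acetyl on this nitrogen would read remains open.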